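The source may report more compounds than this note shows. Statements on the series, on what has been measured and on what is new or still open speak of the compounds shown alone.

The compounds measured so far:

Compound 1, `O=C1/C(=C/c2coc3ccccc3c2=O)N=C(c2ccccc2)N1c1ccc(S(=O)(=O)Nc2nccs2)cc1`: in a functional assay on MCF7 cells (Homo sapiens) for cytotoxicity, read by sulforhodamine B assay, with a stated time of 72 h (on this read-out higher numbers stand for weaker inhibition and lower numbers for stronger inhibition), compound 1 gives 88500 nM.
Compound 2, `NS(=O)(=O)c1ccc(NC2=NC(=O)/C(=C\c3coc4ccccc4c3=O)S2)cc1`: in this assay compound 2 gives 8910 nM.
Compound 3, `O=c1c(CNc2ccc(S(=O)(=O)Nc3ncccn3)cc2)coc2ccccc12`: in this assay compound 3 reached only a limit of the assay, recorded as > 100000 nM.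

Of the two compounds that returned a number, compound 2 has the lowest value; the nearest, compound 1, sits a good deal higher, a gap beyond the usual scatter. Compound 3 gave only a limit and so cannot be ranked against the others. Among the compounds with values here, no two of the measured compounds differ in a single place, so no single structural step has yet been measured in this set.

Compound 4, `Cc1cc(C)nc(NS(=O)(=O)c2ccc(NC3=NC(=O)/C(=C\c4coc5ccccc5c4=O)S3)cc2)n1`, remains to be tested. It differs from compound 2 by 4,6-dimethylpyrimidin-2-yl in place of hydrogen on a sulfonamide nitrogen; in words, 4,6-dimethylpyrimidin-2-yl in place of hydrogen on a sulfonamide nitrogen. Compounds 1 and 3 carry other groups on a sulfonamide nitrogen, but they also have different cores, so they do not isolate this change. In this assay the move from compound 2 to compound 4 is expected to be small, if anything toward a higher number, and probably not beyond the scatter. Compound 4 is therefore estimated at 15000 nM, within 4000 nM to 60000 nM. The expected step is a 1.7-fold higher number from compound 2 to compound 4 (0.23 log units; within the scatter).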

Compound 4, half-maximal inhibitory concentration: > 100000 nM
Compound 4: only a limit was reported; the forecaster's own chance of this, stated with the estimate: 10%; at least 6.6-fold (0.82 log units) between middle value and limit.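

In this assay, placing 4,6-dimethylpyrimidin-2-yl in place of hydrogen on a sulfonamide nitrogen gives an at least 11-fold higher number from compound 2 to compound 4 (1.05 log units; beyond the scatter), the first measured sign in this set that a change at this position can clearly weaken the effect on these cells. Compound 4 gives > 100000 nM, which is a limit of the assay and not a number. The full size of the loss therefore cannot be read, and this ceiling is reached by a sizeable share of the small set: the limit of > 100000 nM in this assay, at which 2 of the 4 values shown sit.

The compounds shown do not tell whether the loss belongs to the pyrimidine ring itself or to its two methyl groups, a question that a plain pyrimidin-2-yl group on the same nitrogen of the shared core would address. They also leave open whether any substituent there can be accepted, since a single large group is the only replacement for hydrogen shown on this core, and a small methyl or acetyl group on that nitrogen would test this.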